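What Removing the Remaining Fluoro Might Do

The compounds below may be only part of what the source reports. "The series", "measured", "known", "first", "only" and "open" are said of these compounds alone.

Three related compounds share a core and were tested in a functional assay on IGROV-1 cells (Homo sapiens) for inhibition; a higher number here means a weaker inhibitor of growth, a lower number a stronger inhibitor of growth. Compound 1 `Nc1ccc(-c2nc3ccc(F)cc3s2)cc1Cl` gives < 10 nM, which is a limit of the assay and not a number. Compound 2 `Cc1cc(-c2nc3cc(F)c(F)cc3s2)ccc1N` gives < 10 nM, which is also a limit. Among the measured compounds shown here, compound 3 `Cc1cc(-c2nc3ccc(F)cc3s2)ccc1N` gives 1300 nM, the only actual number of the three, and it is the weaker inhibitor of growth in both comparisons.

Compound 4 `Cc1cc(-c2nc3ccccc3s2)ccc1N` differs from compound 3 in one place: hydrogen in place of fluoro on an aromatic carbon. This is hydrogen in place of fluoro on an aromatic carbon, and it leaves compound 4 with no fluoro.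

For the measured compounds named here, two measured steps bear on this change, and both are large and beyond the scatter. The first is the same kind of swap: an at least 130-fold higher number from compound 2 to compound 3 (2.11 log units; beyond the scatter). The second puts methyl in place of chloro: an at least 130-fold higher number from compound 1 to compound 3 (2.11 log units; beyond the scatter). Taken alone, the first hints at another rise. However, compound 3 at 1300 nM stands apart from both of its relatives, so a return toward them seems more likely, though this is uncertain. The expected change is a 33-fold lower number from compound 3 to compound 4 (1.51 log units; beyond the scatter), a drop in the number. For compound 4 the estimate is 40 nM, with an expected range from 5 nM to 1300 nM.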

Compound 4, concentration for 50% growth inhibition: < 10 nM
Compound 4 was reported as a limit (the forecaster's own chance of this, stated with the estimate: 50%); middle value at least 4.0-fold (0.60 log units) away from the limit.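

In this assay, hydrogen in place of fluoro on an aromatic carbon can move the number in either direction: removing the fluoro that compound 3 keeps gives an at least 130-fold lower number from compound 3 to compound 4 (2.11 log units; beyond the scatter), whereas the same kind of swap at the other fluoro-bearing carbon gives an at least 130-fold higher number from compound 2 to compound 3 (2.11 log units; beyond the scatter). Compound 4 gives < 10 nM, which is a limit of the assay and not a number, so the drop may be larger than the printed step. Compound 4 carries no fluoro at all, which shows that, among these compounds, strong inhibition of growth does not require fluoro on this ring, while those at the limit cannot be ranked against one another: the limit of < 10 nM in this assay, at which 3 of the 4 values shown sit.

On these data alone, whether a methoxy group or a nitrile on this aromatic carbon would also keep the number low remains open. The compounds shown also offer no explanation of why compound 3, with its single fluoro, stands so far from compound 2 and compound 4, the two compounds that differ from it by one fluoro.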